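The compounds below may be only part of what the source reports. "The series", "measured", "known", "first", "only" and "open" are said of these compounds alone.

Measured so far:
compound 1, `O=C(CCCCCc1ccccc1)OCC1COCCOCCOCCOCCOCCO1`: > 100000 nM
compound 2, `O=C(OCC1COCCOCCOCCOCCOCCO1)c1cccc(-c2ccc(Br)cc2)c1`: 6200 nM

Both compounds carry the same large oxygen-rich ring bearing an ester, and differ only in the group attached to the carbonyl. In a functional assay on WiDr cells (Homo sapiens) for inhibition, read by sulforhodamine B assay, with a stated time of 48 h (on this read-out lower numbers stand for stronger inhibition of growth and higher numbers for weaker inhibition of growth), compound 1 gives only > 100000 nM, which is a limit of the assay and not a measured number. Compound 2, with an aromatic group on the carbonyl, gives 6200 nM in this assay. Within the data shown here, compound 1 thus stands at the limit of > 100000 nM in this assay, at which 1 of the 2 values shown sits, and no measured step leads away from it.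

The next compound, compound 3 `O=C(/C=C/c1ccccc1)OCC1COCCOCCOCCOCCOCCO1`, alters the group on the carbonyl: 2-phenylethenyl in place of 5-phenylpentyl on a carbonyl carbon. The saturated chain of compound 1 gives way to a shorter group whose double bond joins the aromatic ring more closely to the carbonyl.

Compound 1 gives only > 100000 nM, a limit; a step away from such a limit can only run towards lower numbers or stay within the scatter. The step is expected to be an at least 2.0-fold lower number from compound 1 to compound 3 (0.30 log units; that floor lies within the scatter), leaning towards stronger inhibition, though with wide uncertainty. Compound 3 is expected to give about 50000 nM in this assay, within a range from 8000 nM to 300000 nM.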

Compound 3, concentration for 50% growth inhibition: > 100000 nM
Compound 3 gave a limit, no number; the forecaster's own chance of this, stated with the estimate: 50%; middle value at least 2.0-fold (0.30 log units) from the limit.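

In this assay compound 3 also gives only > 100000 nM and this is a limit, not a measured number. Among these compounds, compound 1 stands at a limit too, so no step between compound 1 and compound 3 can be read: (the limit of > 100000 nM in this assay, at which 2 of the 3 values shown sit). Open, going by these compounds, is how far either compound lies from that limit, and which of 2-phenylethenyl and 5-phenylpentyl gives stronger inhibition of growth.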